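Aryl swap on the triazole: compound 2 to compound 3

This account rests on a few compounds, and the source may have more. Where it says the series, first, only, none or still open, it means among the compounds named here.

Measured compounds:
compound 1, `N#CC1=C(N)Oc2c(c3nc4ccccc4nc3c3ccccc23)C12C(=O)N(Cc1cnnn1-c1ccc(N)cc1)c1ccccc12`, > 50000 nM
compound 2, `Cc1ccccc1-n1nncc1CN1C(=O)C2(C(C#N)=C(N)Oc3c(N)cc4nc5ccccc5nc4c32)c2ccccc21`, 31700 nM

Compound 1 has the structure `N#CC1=C(N)Oc2c(c3nc4ccccc4nc3c3ccccc23)C12C(=O)N(Cc1cnnn1-c1ccc(N)cc1)c1ccccc12`. In a functional assay on A549 cells (Homo sapiens) for antiproliferative activity, read by MTT assay, with a stated time of 48 h (on this read-out lower numbers stand for stronger inhibition and higher numbers for weaker inhibition), compound 1 reaches only the limit of the measurement, > 50000 nM, which is not a number. Going by the values given here, compound 2, `Cc1ccccc1-n1nncc1CN1C(=O)C2(C(C#N)=C(N)Oc3c(N)cc4nc5ccccc5nc4c32)c2ccccc21`, is the one compound with an actual number: in this assay compound 2 gives 31700 nM. Among the compounds with values here, of the two values shown, one is a limit, and that is where compound 1 sits (the limit of > 50000 nM in this assay, at which 1 of the 2 values shown sits), so compound 2 supplies the only number from which to reason.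

Compound 3, `N#CC1=C(N)Oc2c(N)cc3nc4ccccc4nc3c2C12C(=O)N(Cc1cnnn1-c1cc(Cl)ccc1Cl)c1ccccc12`, is not yet measured. It differs from compound 2 in one place: 2,5-dichlorophenyl in place of 2-methylphenyl on an aromatic nitrogen.

No step between two measured compounds is available, so the size of this change cannot be read from any pair shown. The account therefore expects a small move in this assay, not clearly beyond the scatter in either direction. Compound 3 is estimated at 25000 nM, with a range from 8000 nM to 80000 nM, which would be a step of a 1.3-fold lower number from compound 2 to compound 3 (0.10 log units; within the scatter).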

Compound 3, half-maximal inhibitory concentration: 10900 nM
For compound 3 the middle estimate is 2.3-fold (0.36 log units) above the measured one, within the range that was stated.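

In this assay, the aryl group on the aromatic nitrogen of the five-membered aromatic ring with 3 nitrogen proves to be a place where a single swap can be read: 2,5-dichlorophenyl in place of 2-methylphenyl gives a 2.9-fold lower number from compound 2 to compound 3 (0.46 log units; beyond the scatter). The earlier compounds shown here could not show this, since compound 2 stood alone with a number and compound 1 differs from it in more than one place. The two groups match in their one six-membered aromatic ring of carbon only, in having 0 hydrogen-bond donors and 0 hydrogen-bond acceptors, and in carrying no net charge, but nothing measured here gives a cause for the step.

The swap removes the methyl group and brings in both chlorine atoms at once, so the compounds shown leave open which of these changes carries the step. Also open, as far as these compounds go, is how this place would respond to a methoxy group or a carboxylic acid on the phenyl ring, or to a benzyl group in place of the phenyl ring.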